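Quinolin-8-yl for 4-Nitrophenyl on a Ring-Bound Sulfonamide

A few compounds are considered here, and "the series" means these few. Any claim that something is new, unique, unknown or untested is made for them only; others in the source may bear on it.

Compound 1, `C=C(CC)C(=O)c1ccc(OCC(=O)NCCNS(=O)(=O)c2ccc([N+](=O)[O-])cc2)c(Cl)c1Cl`, gives 580 nM in a functional assay on HL-60 cells (Homo sapiens) for cytotoxicity, read by luminescence; a lower number here means a stronger inhibitor, a higher number a weaker inhibitor.
Compound 2, `C=C(CC)C(=O)c1ccc(OCC(=O)NCCNS(=O)(=O)c2cccc3cccnc23)c(Cl)c1Cl`, gives 1330 nM in this assay.
Compound 3, `C=C(CC)C(=O)c1ccc(OCC(=O)N2CCN(S(=O)(=O)c3ccc([N+](=O)[O-])cc3)CC2)c(Cl)c1Cl`, gives 3260 nM in this assay.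

Between compound 1 and compound 2 the single change is quinolin-8-yl in place of 4-nitrophenyl on a sulfonyl sulfur; this gave a 2.3-fold higher number from compound 1 to compound 2 (0.36 log units; beyond the scatter). Compound 3 stands highest of the three, and compound 2 is the nearest to it. How the core of compound 3 differs from the core of compound 1 is not broken down here.

Compound 4, `C=C(CC)C(=O)c1ccc(OCC(=O)N2CCN(S(=O)(=O)c3cccc4cccnc34)CC2)c(Cl)c1Cl`, is not yet measured. It differs from compound 3 by quinolin-8-yl in place of 4-nitrophenyl on a sulfonyl sulfur. The place is not the same as in the earlier pair: there the sulfonyl sulfur's other neighbour was a sulfonamide nitrogen, here it is a sulfonamide nitrogen in a ring, so this is the same kind of change rather than the same change. The expectation rests on compound 1 and compound 2, whose step was a 2.3-fold higher number from compound 1 to compound 2 (0.36 log units; beyond the scatter). A step of about the same size is expected, a 2.3-fold higher number from compound 3 to compound 4 (0.36 log units; beyond the scatter), in this assay. Compound 4 is therefore estimated at 7500 nM, with a likely range from 3200 nM to 18000 nM.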

Compound 4, half-maximal inhibitory concentration: 2980 nM
Compound 4: the middle estimate sits 2.5-fold (0.40 log units) above what was measured; measured number outside the range, below it.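

In this assay, quinolin-8-yl in place of 4-nitrophenyl on a sulfonyl sulfur whose other neighbour is a sulfonamide nitrogen in a ring gave a 1.1-fold lower number from compound 3 to compound 4 (0.04 log units; within the scatter), so the two compounds stand level, while the same kind of change on the other core gave a step beyond the scatter. Even so, the two steps cannot be told apart: the same change on two cores in this assay, a 2.3-fold higher number (0.36 log units; beyond the scatter) from compound 1 to compound 2 and a 1.1-fold lower number (0.04 log units; within the scatter) from compound 3 to compound 4, 2.5-fold (0.40 log units) apart, within the scatter of two such steps. The data therefore do not show that the change behaves differently on the two cores, nor do they show that it carries over with a fixed size, as two pairs in a single assay can neither establish nor exclude a modest dependence on the core.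

The compounds shown leave open how an unsubstituted phenyl or a 4-aminophenyl on the sulfonyl sulfur would stand on either core. They also leave open whether a third core would give a step closer to the first pair or to the second.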